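Nitro for Trifluoromethyl on a Diaryl Urea Scaffold

This account rests on a few compounds, and the source may have more. Where it says the series, first, only, none or still open, it means among the compounds named here.

Compound 1, `CCC1(CC)CC(C)(C)Oc2ccc(NC(=O)Nc3ccc(C(F)(F)F)cc3)cc21`: 93.3%
Compound 2, `CCC1(CC)CC(CC)(CC)c2cc(NC(=O)Nc3ccc(C(F)(F)F)cc3)ccc2O1`: 86.2%
Compound 3, `CCC1(CC)CC(CC)(CC)c2cc(NC(=O)Nc3ccc([N+](=O)[O-])cc3)ccc2O1`: 91.4%

All three compounds were measured in a functional assay on A2780 cells (Homo sapiens) for inhibition, with a stated time of 72 h, tested at 10 uM; on this read-out higher numbers stand for more inhibition of growth at the one concentration tested and lower numbers for less inhibition of growth. Compound 1 and compound 2 share the diaryl urea part but carry different cores; the difference between the two cores is not broken down here. Compound 3 is compound 2 with one change, (nitro in place of trifluoromethyl on an aromatic carbon), and the step is a number 5.2 percentage points higher from compound 2 to compound 3 (within the scatter), so the swap made no real difference on the core of compound 2. The three values are all close to one another, and none can be set apart from the others on this read-out.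

Compound 4, `CCC1(CC)CC(C)(C)Oc2ccc(NC(=O)Nc3ccc([N+](=O)[O-])cc3)cc21`, has not yet been measured. It is compound 1 with the same change, (nitro in place of trifluoromethyl on an aromatic carbon), on the other core. Since the place of the change is the same in both pairs, the step from compound 1 to compound 4 is expected to be small, near a number 0.7 percentage points higher from compound 1 to compound 4 (within the scatter), because the comparable step a number 5.2 percentage points higher from compound 2 to compound 3 (within the scatter) lay within the scatter. On that basis compound 4 is estimated to give 94% in this assay, with a likely range from 85% to 100%.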

Compound 4, percent growth inhibition at one concentration: 93.7%
The estimate for compound 4 lay 0.3 percentage points above the measured number; the range from low to high includes it.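

On the core of compound 1, putting nitro in place of trifluoromethyl gives, in this assay, a number 0.4 percentage points higher from compound 1 to compound 4 (within the scatter), so the swap made no real difference here either. Set side by side, the two cores respond to this change alike as far as this read-out can tell: the same change on two cores in this assay, a number 5.2 percentage points higher (within the scatter) from compound 2 to compound 3 and a number 0.4 percentage points higher (within the scatter) from compound 1 to compound 4, 4.8 percentage points apart, within the scatter of two such steps. The change therefore carried over from one core to the other without a visible shift, but this does not show that nitro and trifluoromethyl are interchangeable in general, and a read-out at one concentration cannot tell whether the compounds would still match at lower concentrations.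

The compounds shown leave open how other groups in the same place on the aromatic ring, such as a chlorine atom, a nitrile or an amine, would behave on either core. Also open, as far as these compounds go, is whether the urea that joins the two halves could give way to another link, such as an amide.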